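Swapping chloro for iodo on a weak inhibitor

A few compounds are considered here, and "the series" means these few. Any claim that something is new, unique, unknown or untested is made for them only; others in the source may bear on it.

Compound 1 `CC[Si](C#Cc1cccc2c1OC(C(F)(F)F)C([N+](=O)[O-])=C2)(CC)CC`: 6150 nM
Compound 2 `O=[N+]([O-])C1=Cc2cc(Cl)ccc2OC1C(F)(F)F`: 30800 nM

In an assay on 1321N1 cells for antagonist activity at P2Y purinoceptor 6 (Mus musculus), read by FLIPR and calcium flux (on this read-out higher numbers stand for weaker inhibition and lower numbers for stronger inhibition), compound 2 gives 30800 nM, the highest of the two numbers and thus the weaker inhibitor; compound 1 gives 6150 nM, a gap beyond the scatter. Compound 3 `O=[N+]([O-])C1=Cc2cc(I)ccc2OC1C(F)(F)F` keeps the core of compound 2 and differs in one place: iodo in place of chloro on an aromatic carbon. Among the compounds with values here, no measured pair shows what this exchange does here. A modest move toward stronger inhibition, not clearly beyond the scatter, is expected, so compound 3 is expected to give 15000 nM, within 5000 nM to 45000 nM. The step from compound 2 to compound 3 is estimated at a 2.1-fold lower number from compound 2 to compound 3 (0.31 log units; beyond the scatter).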

Compound 3, half-maximal inhibitory concentration: 28700 nM
Compound 3: middle estimate off by 1.9-fold (0.28 log units), on the low side; the range from low to high includes it.
By their numbers in this assay, from the lowest: compound 1; then compounds 3 and 2 (each within the scatter of the next).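

In this assay, iodo in place of chloro on this aromatic carbon gives a 1.1-fold lower number from compound 2 to compound 3 (0.03 log units; within the scatter), so the read-out does not tell these two halogens apart at this position. Within the data shown here, this is the first measured pair for the exchange on the shared core. Nothing available explains the result. Still open, on these data alone, is whether an amine or a carboxylic acid on the same aromatic carbon would give a number clearly different from those of compound 2 and compound 3.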